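Triaryl pyridines with a hydroxyphenyl arm: moving the hydroxyl

The source may hold more compounds than are shown below. What is called first, only, known or untested is meant among the compounds shown, and "the series" means these compounds.

Measured compounds:
compound 1 `Oc1cccc(-c2cc(-c3ccccc3)cc(-c3ccccc3)n2)c1` — 0%
compound 2 `Oc1cccc(-c2cc(-c3ccccc3)cc(-c3ccncc3)n2)c1` — 25.4%

In an assay on isolated protein for inhibition of DNA topoisomerase 1 (Homo sapiens), with a stated time of 30 min, tested at 20 uM (a higher number here means a stronger effect of the compound at the concentration tested, a lower number a weaker effect), compound 1 gives 0%, the lowest of the two numbers. In this assay, going by the values given here, compound 2 gives 25.4%, and the only measured step, a number 25.4 percentage points higher from compound 1 to compound 2 (beyond the scatter), comes from pyridin-4-yl in place of phenyl on an aromatic carbon.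

Compound 3 `Oc1ccc(-c2cc(-c3ccccc3)cc(-c3ccccc3)n2)cc1` is not yet measured. The change from compound 1 is 4-hydroxyphenyl in place of 3-hydroxyphenyl on an aromatic carbon. Among the compounds with values here, no measured step touches the hydroxyphenyl arm: the step from compound 1 to compound 2 alters a different ring and therefore gives no direct guide. Since compound 1 already reads at the bottom of the scale in this assay, a step downward cannot show, and a step upward beyond the scatter is not expected without a precedent. Compound 3 is expected to read near 8%, within 0% to 30%, an expected step of a number 8 percentage points higher from compound 1 to compound 3 (within the scatter).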

Compound 3, a percentage reported as inhibition, at one concentration (the size of the read-out at that concentration, not a potency): 43.6%
The estimate for compound 3 lay 35.6 percentage points below the measured number; measured number above the stated range.
By their numbers in this assay, from the lowest: compound 1; then compound 2; then compound 3.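

In this assay the arm next to the ring nitrogen responds to the place of the hydroxyl alone: with the same atoms joined differently on an unchanged core, 4-hydroxyphenyl in place of 3-hydroxyphenyl gives a number 43.6 percentage points higher from compound 1 to compound 3 (beyond the scatter) as the step. Going by these compounds alone, the earlier pair differed in another ring, so this is the first sign that the hydroxyphenyl arm itself moves this read-out at the concentration tested. No available evidence bears on the reason for this step.

Open, going by these compounds, is what 4-hydroxyphenyl and pyridin-4-yl do together on one core. Also open, on these data alone, is whether the hydroxyl itself is needed at this place, or whether a methoxy group, an amine or a carboxylic acid in the same place on the ring would hold the read-out.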